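Aryl urea series: ethoxycarbonyl in place of trifluoromethyl

This account rests on a few compounds, and the source may have more. Where it says the series, first, only, none or still open, it means among the compounds named here.

Compound 2 `C[C@@H](NC(=O)Nc1ccc(C(F)(F)F)cc1)c1ccccc1` gives 93% in an ADME assay on the whole organism with Oryza sativa as the target, tested at 0.1 uM; on this read-out higher numbers stand for a weaker effect at the one concentration tested and lower numbers for a stronger effect; this is the lowest of the two numbers in hand, and the nearest is compound 1 `CCc1ccc(NC(=O)N[C@H](C)c2ccccc2)cc1` with 95%, a gap within the scatter. Going by the values given here, the only measured step, a number 2 percentage points lower from compound 1 to compound 2 (within the scatter), left the read-out essentially unchanged when trifluoromethyl replaced ethyl on an aromatic carbon. Compound 3 `CCOC(=O)c1ccc(NC(=O)N[C@H](C)c2ccccc2)cc1` differs from compound 2 in one place: ethoxycarbonyl in place of trifluoromethyl on an aromatic carbon. Among the compounds with values here, no measured step covers an ethoxycarbonyl entering, so the expectation rests on the two numbers available, which agree within the scatter and suggest that this position tolerates exchange without a large shift. Compound 3 is therefore expected to show a step of no change at the digits printed from compound 2 to compound 3 (within the scatter) in this assay, nothing beyond the scatter. The estimate for compound 3 is 93%, with a range from 84% to 100%.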

Compound 3, a percentage reported as activity, at one concentration (the size of the read-out at that concentration, not a potency): 101%
Beside the measured number, compound 3's estimate is 8 percentage points below it; measured number outside the range, above it.
By their numbers in this assay, from the lowest: compounds 2, 1 and 3 (each within the scatter of the next).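

In this assay the exchange reads as a number 8 percentage points higher from compound 2 to compound 3 (within the scatter), and against the ethyl compound as a number 6 percentage points higher from compound 1 to compound 3 (within the scatter). Ethoxycarbonyl, the first group here at this position with a double bond outside the aromatic rings and with hydrogen-bond acceptors, therefore does not separate from either trifluoromethyl or ethyl on this read-out, and all three compounds remain within the scatter of each other at the one concentration tested. No supporting measurement bears on this result.

On these data alone, whether a free carboxylic acid, an amine or a longer alkyl chain on this aromatic carbon would move the read-out beyond the scatter remains open. Also open, as far as these compounds go, is whether these three compounds would stay together at other concentrations.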